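A few compounds are considered here, and "the series" means these few. Any claim that something is new, unique, unknown or untested is made for them only; others in the source may bear on it.

Compound 1 `CCN1CCN(c2nc(Nc3ccc(C(=O)NC4CC(C)(C)N([O])C(C)(C)C4)cc3)ncc2[N+](=O)[O-])CC1` gives 39700 nM
Compound 2 `Cc1cc(Nc2nc(Nc3ccc(C(=O)NC4CC(C)(C)N([O])C(C)(C)C4)cc3)ncc2[N+](=O)[O-])no1` gives 26800 nM
Compound 3 `Cc1cc(Nc2nc(Nc3ccc(C(=O)NC4CC(C)(C)N([O])C(C)(C)C4)cc3)ncc2[N+](=O)[O-])n[nH]1` gives > 100000 nM (a limit, not a true number)

For the measured compounds named here, in a functional assay on LoVo cells (Homo sapiens) for antiproliferative activity, read by MTT assay, with a stated time of 48 h (on this read-out lower numbers stand for stronger inhibition and higher numbers for weaker inhibition), compound 1 lies within the usual scatter of compound 2, the only other true number here. Compound 3 reached only the limit > 100000 nM in this measurement.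

Compound 4 `CCOC(=O)Cc1csc(Nc2nc(Nc3ccc(C(=O)NC4CC(C)(C)N([O])C(C)(C)C4)cc3)ncc2[N+](=O)[O-])n1` carries (4-((ethoxycarbonyl)methyl)-1,3-thiazol-2-yl)amino in place of 4-ethylpiperazin-1-yl on an aromatic carbon of compound 1 ((4-((ethoxycarbonyl)methyl)-1,3-thiazol-2-yl)amino in place of 4-ethylpiperazin-1-yl on an aromatic carbon). Two measured steps replace that same group with a different ring-bearing amino group. Of these, a 1.5-fold lower number from compound 1 to compound 2 (0.17 log units; within the scatter) stays within the scatter, whereas an at least 2.5-fold higher number from compound 1 to compound 3 (0.40 log units; beyond the scatter) goes beyond it and ends at a limit. Neither ring matches the new one, so the expected size in this assay is none beyond the scatter, with a 1.3-fold lower number from compound 1 to compound 4 (0.12 log units; within the scatter) as the estimated step. Compound 4 is expected at 30000 nM with a range from 11000 nM to 85000 nM on this estimate.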

Compound 4, half-maximal inhibitory concentration: 27000 nM
The estimate for compound 4 lay 1.1-fold (0.05 log units) above the measured number; low and high end bracket the measured number.
By their numbers in this assay, from the lowest: compounds 2, 4 and 1 (each within the scatter of the next). At a limit, above all of these: compound 3.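

On the aromatic carbon ortho to a nitro group, a group of more heavy atoms than 4-ethylpiperazin-1-yl, carrying a 1,3-thiazole ring and an ethyl ester, is tolerated, with a 1.5-fold lower number from compound 1 to compound 4 (0.17 log units; within the scatter) and a 1.0-fold higher number from compound 2 to compound 4 (0.00 log units; within the scatter). For the compounds shown here, the one step beyond the scatter involves the pyrazole-bearing compound, with an at least 3.7-fold lower number from compound 3 to compound 4 (0.56 log units; beyond the scatter). Compound 3 sits at a limit, so that step has no true size: the limit of > 100000 nM in this assay, at which 1 of the 4 values shown sits.

From the compounds shown here alone, whether a free carboxylic acid in place of the ethyl ester, or a simple primary amine at this carbon, would move the number beyond the scatter remains open.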